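A Fluorine on the Outer Ring of Compound 3

The compounds below may be only part of what the source reports. "The series", "measured", "known", "first", "only" and "open" are said of these compounds alone.

In an assay on HEK293 cells for displacement of a labelled ligand from C-X-C chemokine receptor type 3 (Homo sapiens) (on this read-out higher numbers stand for weaker inhibition and lower numbers for stronger inhibition), the three measured compounds stand as follows:
Compound 1, `CN(CC1=CC[C@H]2C[C@@H]1C2(C)C)Cc1ccccc1`, gives 15800 nM
Compound 2, `CN(CC1=CC[C@H]2C[C@@H]1C2(C)C)Cc1ccc(Br)cc1`, gives 3160 nM
Compound 3, `CN(CC1=CC[C@H]2C[C@@H]1C2(C)C)Cc1ccc(-c2ccccc2)cc1`, gives 3160 nM

Compound 3 is level with compound 2 at the digits shown, the two together the lowest of the three numbers, while compound 1 lies furthest away, separated by the step of a 5.0-fold lower number from compound 1 to compound 3 (0.70 log units; beyond the scatter).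

Compound 4, `CN(CC1=CC[C@H]2C[C@@H]1C2(C)C)Cc1ccc(-c2cccc(F)c2)cc1`, differs from compound 3 by fluoro in place of hydrogen on an aromatic carbon. Within the data shown here, no measured step adds a small group to this outer ring. The nearest comparisons all concern the inner ring: a 5.0-fold lower number from compound 1 to compound 2 (0.70 log units; beyond the scatter) and a 5.0-fold lower number from compound 1 to compound 3 (0.70 log units; beyond the scatter) are modest, and no change at the digits printed from compound 2 to compound 3 (within the scatter) lies within the scatter. A step of a 1.1-fold lower number from compound 3 to compound 4 (0.02 log units; within the scatter) is therefore expected, not beyond the scatter. Compound 4 is estimated at 3000 nM, within 1000 nM to 10000 nM.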

Compound 4, inhibition constant: 2510 nM
Compound 4: the middle estimate sits 1.2-fold (0.08 log units) above what was measured, within the range that was stated.
By their numbers in this assay, from the lowest: compounds 4, 2 and 3 (each within the scatter of the next); then compound 1.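

On the outer ring, fluoro in this assay leaves the number within the scatter (a 1.3-fold lower number from compound 3 to compound 4 (0.10 log units; within the scatter)), so this position accepts the change without a measurable shift. Replacing bromo with 3-fluorophenyl also stays within the scatter (a 1.3-fold lower number from compound 2 to compound 4 (0.10 log units; within the scatter)), while the step from the unsubstituted benzyl compound remains modest (a 6.3-fold lower number from compound 1 to compound 4 (0.80 log units; beyond the scatter)). No evidence is available to explain these results. The compounds shown leave open whether a hydroxyl, an amine or a carboxylic acid at this position of the outer ring would move the number beyond the scatter.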